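Replacing the (piperidin-4-yl)oxy group of compound 2

This account rests on a few compounds, and the source may have more. Where it says the series, first, only, none or still open, it means among the compounds named here.

Measured in an ADME assay on microsomes from liver (Homo sapiens) for metabolic stability, read by LC-MS, tested at 1 uM; a lower number here means slower removal, a higher number faster removal of the compound:
Compound 1 `NCCOCCOc1ccc([C@H]2CC[C@]3(CC2)OOC2(O3)C3CC4CC(C3)CC2C4)cc1`: < 7 mL.min-1.g-1
Compound 2 `c1cc([C@H]2CC[C@]3(CC2)OOC2(O3)C3CC4CC(C3)CC2C4)ccc1OCCOC1CCNCC1`: < 7 mL.min-1.g-1

Compound 2 has no exact place on this scale, since it reports only a limit, < 7 mL.min-1.g-1. Compound 1 also reports only a limit, < 7 mL.min-1.g-1. The series thus far shows (the limit of < 7 mL.min-1.g-1 in this assay, at which 2 of the 2 values shown sit).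

Compound 3 `CC(C)(O)CNCCCOc1ccc([C@H]2CC[C@]3(CC2)OOC2(O3)C3CC4CC(C3)CC2C4)cc1` differs from compound 2 in its side chain: ((2-hydroxy-2-methylpropyl)amino)methyl in place of (piperidin-4-yl)oxy on a saturated chain carbon, two bonds along the chain from an oxygen on an aromatic ring. The change is ((2-hydroxy-2-methylpropyl)amino)methyl in place of (piperidin-4-yl)oxy, on a saturated chain carbon.

Among the compounds with values here, the only measured step that bears on this is a step that the two limits leave unreadable from compound 1 to compound 2. It gives no size to carry over, so no step beyond the scatter can be argued from it, and no direction either. Compound 3 is therefore expected to stay close to the limit of compound 2, < 7 mL.min-1.g-1. The expected change is a step that the limit leaves unreadable from compound 2 to compound 3. For compound 3 the estimate in this assay is 6 mL.min-1.g-1, with an expected range of 3 mL.min-1.g-1 to 14 mL.min-1.g-1.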

Compound 3, intrinsic clearance in microsomes: 8 mL.min-1.g-1
Beside the measured number, compound 3's estimate is 1.3-fold (0.12 log units) below it; the range from low to high includes it.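

In this assay, within the data shown here, compound 3 gives the first exact reading of the series, 8 mL.min-1.g-1, so the ((2-hydroxy-2-methylpropyl)amino)methyl group on this saturated chain carbon now has a number where the earlier compounds had none. Going by these compounds, in place of (piperidin-4-yl)oxy the change reads as an at least 1.1-fold higher number from compound 2 to compound 3 (0.05 log units; that floor lies within the scatter), and in place of 2-aminoethoxy as an at least 1.1-fold higher number from compound 1 to compound 3 (0.05 log units; that floor lies within the scatter); each is only a floor, so neither step shows a shift beyond the scatter and the true size of both remains unknown. Most of the series still sits at a limit of the assay: the limit of < 7 mL.min-1.g-1 in this assay, at which 2 of the 3 values shown sit.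

On these data alone, whether the hydroxyl of the new chain matters stays open, as a plain 2-methylpropylamino chain would be needed to tell. As far as these compounds go, how a morpholine or a carboxylic acid at this place would read is also open.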